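Adding a Methylsulfamoyl Group to an Ethyl Side Chain

This account rests on a few compounds, and the source may have more. Where it says the series, first, only, none or still open, it means among the compounds named here.

Within the data shown here, in a functional assay on the whole organism with Rattus norvegicus as the target (a lower number here means that less compound is needed, a higher number that more compound is needed for the effect), compound 2 `CCn1c(=N)sc2cc(OC(F)(F)F)ccc21` gives 5 mg/kg, the only plain number reported in this set. Compound 1 `Nc1nc2ccc(C3CCCCC3)cc2s1` gives > 10 mg/kg in this assay, which is a limit rather than a number, so the limit of > 10 mg/kg in this assay, at which 1 of the 2 values shown sits, describes where it sits. Compound 3 `CNS(=O)(=O)CCn1c(=N)sc2cc(OC(F)(F)F)ccc21` is compound 2 with a single change: methylsulfamoyl in place of hydrogen on a saturated chain carbon, two bonds along the chain from an aromatic nitrogen. Among the measured compounds shown here, no measured pair shows what such a change does in this assay, so its direction cannot be read from the data. The step of a 1.4-fold higher number from compound 2 to compound 3 (0.15 log units; within the scatter) is expected to lie within the usual scatter. Compound 3 is therefore estimated at 7 mg/kg, with a range from 2 mg/kg to 25 mg/kg.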

Compound 3, dose for half-maximal effect: 4 mg/kg
Compound 3: the middle estimate sits 1.8-fold (0.24 log units) above what was measured; measured number inside the range.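

In this assay, among these compounds, the step of a 1.3-fold lower number from compound 2 to compound 3 (0.10 log units; within the scatter) gives the first measured pair for this change. It shows that the ethyl chain of compound 2 can carry methylsulfamoyl, with its 5 heavy atoms, on a saturated chain carbon, two bonds along the chain from an aromatic nitrogen, with no change beyond the scatter. Nothing measured here explains this result.

From the compounds shown here alone, whether an amine or a carboxylic acid in the same place, or a longer chain, would also leave the number within the scatter stays open. This single pair also cannot show whether the same change would behave alike on a different core.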